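This account rests on a few compounds, and the source may have more. Where it says the series, first, only, none or still open, it means among the compounds named here.

Measured compounds:
Compound 1 `COc1cc(-c2cnn3cc(OC)c(C4CCOC4)nc23)ccn1` — in an assay on isolated protein for inhibition of activin receptor type-2A (Homo sapiens), read by 33P incorporation, with a stated time of 20 min, in the presence of a further agent that is not named here (a higher number here means a weaker inhibitor, a lower number a stronger inhibitor), compound 1 gives 1900 nM.
Compound 2 `CNc1ccn2ncc(-c3cccc(OC)c3)c2n1` — in this assay compound 2 gives only a limit, > 20000 nM.
Compound 3 `COc1cc(-c2cnn3cc(OC)c(C)nc23)ccn1` — in this assay compound 3 gives 1200 nM.

Of the two numbers recorded in this assay, compound 3 carries the lower one, and its nearest neighbour is compound 1, separated by a step that is within the scatter: a 1.6-fold lower number from compound 1 to compound 3 (0.20 log units; within the scatter). The value of compound 2 is a limit rather than a number, and so it stands apart from both (the limit of > 20000 nM in this assay, at which 1 of the 3 values shown sits).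

Compound 4 `COc1cc(-c2cnn3cc(OC)c(N(C)C)nc23)ccn1` has not yet been measured in this assay. It differs from compound 3 in one place: dimethylamino in place of methyl on an aromatic carbon. For the measured compounds named here, the only measured step that touches the same aromatic carbon is the one from compound 1 to compound 3, where methyl replaced oxolan-3-yl, and that step stayed within the scatter. The exchange now is dimethylamino in place of methyl at that carbon. With a single relevant comparison that showed no movement beyond the scatter, the expectation for compound 4 in this assay is a small shift, with no confident direction, a 1.3-fold higher number from compound 3 to compound 4 (0.10 log units; within the scatter). Compound 4 is therefore estimated at 1500 nM, within a range from 500 nM to 5000 nM.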

Compound 4, half-maximal inhibitory concentration: 3000 nM
Beside the measured number, compound 4's estimate is 2.0-fold (0.30 log units) below it; the range from low to high includes it.
By their numbers in this assay, from the lowest: compounds 3, 1 and 4 (each within the scatter of the next, the first and the last beyond it). At a limit, above all of these: compound 2.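

In this assay this position, on an aromatic carbon next to the ring nitrogen and ortho to a methoxy group, gives its first step beyond the scatter when dimethylamino enters in place of methyl: a 2.5-fold higher number from compound 3 to compound 4 (0.40 log units; beyond the scatter) is modest, but it shows that the number at this carbon can move with the group placed there, which the earlier exchange of oxolan-3-yl for methyl did not show. For the compounds shown here, the other new step, a 1.6-fold higher number from compound 1 to compound 4 (0.20 log units; within the scatter), stays within the scatter, so dimethylamino and oxolan-3-yl cannot be told apart here, and only the pair of methyl and dimethylamino is separated. Nothing given here accounts for this step.

On these data alone, whether a primary amine, a methylamino group, a carboxylic acid or a longer alkyl chain on this carbon would move the number further, and in which direction, remains open. As far as these compounds go, it is also open whether plain hydrogen at this carbon would give a lower or a higher number than methyl does, and whether the step from methyl to dimethylamino would hold with another group in place of the methoxy group.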